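Nitro for methylsulfanyl on a shared oxazoline core

This account rests on a few compounds, and the source may have more. Where it says the series, first, only, none or still open, it means among the compounds named here.

Measured so far:
compound 1, `CSc1ccccc1C1=NC(c2ccccc2)CO1`, 3.5
compound 2, `Fc1cccc(Cl)c1C1=NC(c2ccccc2)CO1`, 3.45

Of the compounds shown here, two have been measured in a physicochemical assay for lipophilicity; a higher number here means a more lipophilic compound, a lower number a more polar compound. Compound 1 stands highest of the two numbers, but its nearest neighbour, compound 2, lies only a small distance lower, and that distance is within the scatter of the method, so the two cannot be ordered on these data.

The step from compound 1 leads to compound 3, `O=[N+]([O-])c1ccccc1C1=NC(c2ccccc2)CO1`, which has not yet been measured. The change is nitro in place of methylsulfanyl on an aromatic carbon, on an aromatic carbon of a six-membered aromatic ring of carbon only, ortho to a large group.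

For the measured compounds named here, no step between measured compounds is available to calibrate this change, so the expectation rests on the values of compound 1 alone. Compound 3 is expected to read lower than compound 1, by a step of a number 0.90 log units lower from compound 1 to compound 3 (beyond the scatter), which would lie beyond the scatter. On that basis compound 3 is estimated at 2.6, with a range from 2.2 to 3.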

Compound 3, partition coefficient: 2.83
Compound 3: the middle estimate sits 0.23 log units below what was measured; measured number inside the range.
By their numbers in this assay, from the lowest: compound 3; then compounds 2 and 1 (each within the scatter of the next).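

In this assay, the swap of methylsulfanyl for nitro on an aromatic carbon, ortho to a large group, gives a step of a number 0.67 log units lower from compound 1 to compound 3 (beyond the scatter) and so shows that this position can move the read-out by more than the method's scatter. For the compounds shown here, the earlier compounds could not show this, as no two of them differed in one place, and this is therefore the first step that can be read as the effect of a single change. No measurement among the data offers an explanation for the size or direction of this step.

What the compounds shown leave open is how other groups on this aromatic carbon would read in this assay, for instance an amine, a carboxylic acid, a nitrile or a longer chain in place of methylsulfanyl. Going by these compounds alone, with only one step in hand, it also remains open whether the same exchange would give a step of similar size at another place on the ring or on a core carrying further changes.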